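Thiophene-bearing series: sec-butoxy replacing isopropylsulfanyl

The compounds below may be only part of what the source reports. "The series", "measured", "known", "first", "only" and "open" are said of these compounds alone.

Compound 2 `CC1=C(C(=O)SC(C)C)C(c2cccs2)NC(=O)N1` holds the lower of the two numbers in an assay on membranes from HEK293 cells for displacement of a labelled ligand from adenosine receptor A2b (Homo sapiens), read by scintillation counting, with a stated time of 30 min, tested at 1 uM (a higher number here means more inhibition at the concentration tested (going by the name of the read-out), a lower number less inhibition), at 1%; compound 1 `CCN(CC)C(=O)C1=C(C)NC(=O)NC1c1cccs1` gives 22%. For the measured compounds named here, the one step so far, a number 21 percentage points lower from compound 1 to compound 2 (beyond the scatter), concerns a different exchange on the same carbonyl carbon. Compound 3 `CCC(C)OC(=O)C1=C(C)NC(=O)NC1c1cccs1` differs from compound 2 by sec-butoxy in place of isopropylsulfanyl on a carbonyl carbon. Going by the values given here, no measured step compares the two groups involved here, so nothing points to a move beyond the scatter in either direction. Compound 3 is therefore expected to stay near compound 2, at an estimated 6% (range 0% to 22%), a step of a number 5 percentage points higher from compound 2 to compound 3 (within the scatter).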

Compound 3, a percentage reported as inhibition, at one concentration (the size of the read-out at that concentration, not a potency): 7%
Beside the measured number, compound 3's estimate is 1 percentage points below it, within the range that was stated.
By their numbers in this assay, from the lowest: compounds 2 and 3 (each within the scatter of the next); then compound 1.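

In this assay the exchange of isopropylsulfanyl for sec-butoxy on the carbonyl carbon gives a number 6 percentage points higher from compound 2 to compound 3 (within the scatter) and so does not separate the two groups. Sec-butoxy in place of diethylamino gives a number 15 percentage points lower from compound 1 to compound 3 (beyond the scatter) and, with the isopropylsulfanyl step, leaves the diethylamino compound apart from both others. No evidence bears on the reason for this.

Open, as far as these compounds go, is whether another amine on this carbonyl carbon, such as pyrrolidine or dipropylamine, would match or pass compound 1, and whether a longer chain on the oxygen would change the number.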